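The compounds below may be only part of what the source reports. "The series", "measured", "known", "first", "only" and "open" are said of these compounds alone.

Compound 1 `CC(C)C(NC(=O)NO)C(=O)NC1CCCCC1`: in a functional assay on MIA PaCa-2 cells (Homo sapiens) for inhibition (on this read-out lower numbers stand for stronger inhibition and higher numbers for weaker inhibition), compound 1 gives > 100000 nM, a limit of the assay.
Compound 2 `CCC(C)C1NC(=O)N(C2CCCCC2)C1=O`: in this assay compound 2 gives > 100000 nM, a limit of the assay.

Compound 1 therefore stands not at a number but at the edge of what this assay reports; the same holds for compound 2, as the limit of > 100000 nM in this assay, at which 2 of the 2 values shown sit, shows, and the two values show nothing more than that neither compound reaches a measurable inhibition. Within the data shown here, no step between measured compounds bears on the change in question. Compound 3 `CCC(C)C(NC(=O)NO)C(=O)NC1CCCCC1` differs from compound 1 by methyl in place of hydrogen on a saturated chain carbon, three bonds along the chain from an amide-type nitrogen and a carbonyl carbon, a small addition on the side chain. Since compound 1 sits at the limit, the writer expects the step that the limit leaves unreadable from compound 1 to compound 3 to be none beyond the scatter, with compound 3 most probably also returned as a limit in this assay. As a central estimate, compound 3 is expected to give 150000 nM, within a range from 30000 nM to 1000000 nM.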

Compound 3, half-maximal inhibitory concentration: > 100000 nM
Compound 3 was reported as a limit; the forecaster's own chance of this, stated with the estimate: 85%; the middle value lies beyond the limit too.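

Among these compounds, compound 3, like compound 1, is reported only as a limit in this assay, so no step between compound 1 and compound 3 can be read: the limit of > 100000 nM in this assay, at which 3 of the 3 values shown sit. The compounds shown leave open what change, if any, would bring a measurable inhibition in this assay.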